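The source may report more compounds than this note shows. Statements on the series, on what has been measured and on what is new or still open speak of the compounds shown alone.

Three ureas have so far been tested in an ADME assay on BJ cells (Homo sapiens) for cytotoxicity, with a stated time of 72 h; on this read-out higher numbers stand for an effect only at larger amounts of compound and lower numbers for an effect already at smaller amounts. Compound 1 `COc1ccc(NC(=O)Nc2cc(C)nc3ccccc23)cc1F` gives 26000 nM in this assay. Compound 2 `Cc1ccc(NC(=O)Nc2cc(C)nc3ccccc23)cc1` reaches only the limit of this assay, > 25000 nM. Compound 3 `Cc1cc(NC(=O)Nc2cccc(C(N)=O)c2)c2ccccc2n1` likewise gives only a limit in this assay, > 25000 nM. Among the three numbers, compound 3 thus sits at the limit of > 25000 nM in this assay, at which 2 of the 3 values shown sit, without a number of its own. Compound 4 `Cc1cc(NC(=O)Nc2cccc([N+](=O)[O-])c2)c2ccccc2n1` differs from compound 3 in one place: nitro in place of carbamoyl on an aromatic carbon. Within the data shown here, no step between two measured compounds is known here, so the step from compound 3 to compound 4 in this assay is expected to stay within the usual scatter, in either direction. The expected step that the limit leaves unreadable from compound 3 to compound 4 is accordingly small. Compound 4 is estimated at 26000 nM in this assay, between 10000 nM and 60000 nM.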

Compound 4, half-maximal effective concentration: > 25000 nM
Compound 4 was reported as a limit; the forecaster's own chance of this, stated with the estimate: 65%; the middle value lies beyond the limit too.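

Among these compounds, compound 3 and compound 4 both end at a limit rather than a number in this assay, so no step between them can be read: the limit of > 25000 nM in this assay, at which 3 of the 4 values shown sit. The compounds shown leave open whether nitro in place of carbamoyl changes the value at all.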